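Flipping One Stereocentre in a Methoxy Compound

The compounds below may be only part of what the source reports. "The series", "measured", "known", "first", "only" and "open" are said of these compounds alone.

Compound 1 `O=C1C[C@H]2O[C@H](C(O)O)[C@H](O)[C@H]2O1`: 21000 nM
Compound 2 `CO[C@@H](c1ccccc1)[C@H]1O[C@@H]2CC(=O)O[C@@H]2[C@H]1O`: 5310 nM

These values come from a functional assay on A549 cells (Homo sapiens) for inhibition, read by MTT assay, with a stated time of 72 h (on this read-out higher numbers stand for weaker inhibition and lower numbers for stronger inhibition), so the lower number marks the stronger inhibitor. Compound 2 stands at 5310 nM, the lower of the two numbers, and its gap to compound 1 at 21000 nM lies beyond the usual scatter of repeated measurements.

The next compound is compound 3 `CO[C@H](c1ccccc1)[C@H]1O[C@@H]2CC(=O)O[C@@H]2[C@H]1O`, a close relative of compound 2. The structural change is the two compounds have the same atoms and bonds and differ only in configuration as drawn: 1 of 5 stereo elements differ; a stereocentre at a saturated chain carbon is drawn S in compound 2 and R in compound 3. Such a pair is called a pair of stereoisomers: the same pieces are connected in the same order, but one centre points the other way in space.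

Within the data shown here, no measured pair here differs only in configuration, so the data give no guide to the size or direction of this change. A shift in either direction remains possible, and the estimate below carries a wide range for that reason. The expected result is no change beyond the scatter, shown as a 1.1-fold higher number from compound 2 to compound 3 (0.05 log units; within the scatter). For compound 3 the estimated value is 6000 nM, with an expected range from 1800 nM to 20000 nM.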

Compound 3, half-maximal inhibitory concentration: 2640 nM
The estimate for compound 3 lay 2.3-fold (0.36 log units) above the measured number; low and high end bracket the measured number.
By their numbers in this assay, from the lowest: compounds 3 and 2 (each within the scatter of the next); then compound 1.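

Among these compounds, this is the first measured pair here that differs only in configuration, and in this assay the step is a 2.0-fold lower number from compound 2 to compound 3 (0.30 log units; within the scatter). Drawing this saturated chain carbon R instead of S therefore gives a result that cannot be told apart from repeated measurements of a single compound, and this pair offers no basis for ranking compound 2 and compound 3 against each other. The comparison is a clean one for this single stereocentre, as the rest of the structure stays the same: the fact that compounds 2 and 3 differ only in the configuration as drawn.

The compounds shown leave open whether this position would respond in the same way if the methoxy group gave way to an amine, a carboxylic acid or a longer chain, since a tolerated flip with one group says nothing certain about another. They also leave open what the other four stereo elements contribute, as these are drawn the same way in both compounds, and one pair cannot show whether this result would hold at any other centre of the shared core.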